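Amide-linker variation in a piperazine series of positive modulators

This account rests on a few compounds, and the source may have more. Where it says the series, first, only, none or still open, it means among the compounds named here.

Measured compounds:
- compound 1 `O=C(COCc1ccccc1)N1CCN(c2ccc(F)cc2)CC1`: 1100 nM
- compound 2 `O=C(COCc1ccccc1)N1CCN(c2ccc(F)cc2Cl)CC1`: 270 nM
- compound 3 `O=C(COCc1cnccn1)N1CCN(c2ccc(Cl)cc2Cl)CC1`: 5200 nM

All three numbers come from a functional assay on HEK293 cells for positive allosteric modulation of metabotropic glutamate receptor 5 (Homo sapiens), read by FLIPR and calcium flux; a lower number here means that less compound is needed, a higher number that more compound is needed for the effect. Compound 3 stands at the highest number of the three: against compound 1 the gap is beyond the scatter, and against compound 2 it is larger still. Going by the values given here, the one single-point step measured so far runs a 4.1-fold lower number from compound 1 to compound 2 (0.61 log units; beyond the scatter), a chloro in place of hydrogen on an aromatic carbon, modest in size.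

Compound 4 `O=C(CNCc1ccncc1)N1CCN(c2ccc(Cl)cc2Cl)CC1` differs from compound 3 in one place: ((pyridin-4-yl)methyl)amino in place of (pyrazin-2-yl)methoxy on a saturated chain carbon bound to a carbonyl carbon. Among the compounds with values here, no measured step touches this part of the molecule; the pair compound 1 and compound 3 differs in several places at once and gives no clean reading on the pyrazinylmethoxy group alone. The expectation for compound 4 in this assay therefore rests on little. Within the data shown here, with compound 3 at 5200 nM and no directional precedent, a step of about a 1.5-fold lower number from compound 3 to compound 4 (0.17 log units; within the scatter) is expected, within or near the scatter. Compound 4 is estimated at 3500 nM, with a range from 900 nM to 14000 nM.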

Compound 4, half-maximal effective concentration: 8500 nM
For compound 4 the middle estimate is 2.4-fold (0.39 log units) below the measured one; low and high end bracket the measured number.
By their numbers in this assay, from the lowest: compound 2; then compound 1; then compounds 3 and 4 (each within the scatter of the next).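

In this assay, going by these compounds alone, this is the first reading at the saturated chain carbon bound to a carbonyl carbon: ((pyridin-4-yl)methyl)amino in place of (pyrazin-2-yl)methoxy gives a 1.6-fold higher number from compound 3 to compound 4 (0.21 log units; within the scatter). The exchange keeps the count of 8 heavy atoms but swaps the oxygen for a nitrogen that adds a hydrogen-bond donor and takes one hetero atom out of the six-membered aromatic ring, and this combined change leaves the two numbers within the scatter of each other. No supporting data bear on why the reading stays within the scatter.

Since the linking atom and the aromatic ring change together in this one step, compound 3 and compound 4 cannot say what either change does alone, and a pyridin-4-yl ring on the oxygen link or a pyrazin-2-yl ring on the amino link would separate the two. As far as these compounds go, how much the aromatic ring matters at this place at all also stays open, and a plain dimethylamino group, a carboxylic acid or a longer chain on the same carbon of the shared core would address that.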